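The source may hold more compounds than are shown below. What is called first, only, known or untested is meant among the compounds shown, and "the series" means these compounds.

Of the compounds shown here, three in this set have been tested in a functional assay on DU-145 cells (Homo sapiens) for inhibition, read by trypan blue exclusion, with a stated time of 96 h; a lower number here means a stronger inhibitor of growth, a higher number a weaker inhibitor of growth. Compound 2 `O=C(/C(=C\c1ccc(Br)cc1)Sc1ccc(Br)cc1)c1ccc(Cl)cc1` gives 1000 nM. Compound 1 `Cc1ccc(CS/C(=C/c2ccc(Br)cc2)C(=O)c2ccc(Cl)cc2)cc1` gives 10000 nM, and compound 3 `O=C(/C(=C\c1ccccc1OCc1ccccc1)Sc1ccc(Br)cc1)c1ccc(Cl)cc1` gives 10000 nM. Compound 1 differs from compound 2 in one place only, (4-methylbenzyl in place of 4-bromophenyl on a sulfur), and this single change gave a 10-fold higher number from compound 2 to compound 1 (1.00 log units; beyond the scatter). How the core of compound 3 differs from the core of compound 2 is not broken down here; the two numbers simply stand as they are.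

Compound 4 `Cc1ccc(CS/C(=C/c2ccccc2OCc2ccccc2)C(=O)c2ccc(Cl)cc2)cc1` has not yet been measured in this assay. It differs from compound 3 by 4-methylbenzyl in place of 4-bromophenyl on a sulfur, which is the same change that separates compound 1 from compound 2, made at the same place. For compound 4 a step of about a 2.5-fold higher number from compound 3 to compound 4 (0.40 log units; beyond the scatter) is expected, because the same change gave a 10-fold higher number from compound 2 to compound 1 (1.00 log units; beyond the scatter). The expected value for compound 4 is therefore 25000 nM, with a likely range from 7000 nM to 80000 nM. Going by the values given here, this estimate rests on compound 3, whose value of 10000 nM is the starting point, and on the one earlier step.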

Compound 4, concentration for 50% growth inhibition: 1000 nM
Estimate against measurement, compound 4: 25-fold (1.40 log units) above; the whole stated range lies above it.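

The same swap, 4-methylbenzyl in place of 4-bromophenyl on a sulfur, was read again in this assay on a second core, where it gave a 10-fold lower number from compound 3 to compound 4 (1.00 log units; beyond the scatter) and so ran opposite to the earlier step. Set side by side, the two steps show that in this series the change cannot be carried from one core to another as a fixed shift in growth inhibition: the same change on two cores in this assay, a 10-fold higher number (1.00 log units; beyond the scatter) from compound 2 to compound 1 and a 10-fold lower number (1.00 log units; beyond the scatter) from compound 3 to compound 4, 100-fold (2.00 log units) apart, beyond the scatter of two such steps. Going by these compounds alone, they do not show why the two cores respond differently, and with only two cores and one assay they cannot tell how the change would behave on a third core.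

The swap removes the bromine and lengthens the link to the ring together, so 4-bromobenzyl and 4-methylphenyl on the sulfur, on both cores, would be needed to tell those two parts apart. Also open, as far as these compounds go, is whether a ring carrying an amine or a carboxylic acid in that place would follow either core's trend.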